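The source may hold more compounds than are shown below. What is called first, only, known or untested is meant among the compounds shown, and "the series" means these compounds.

Measured compounds in a functional assay on cells (Platelet, Homo sapiens) for inhibition; on this read-out lower numbers stand for stronger inhibition and higher numbers for weaker inhibition:
compound 1 `CCOC(=O)c1ccc(-c2nn(Cc3ccc(Cl)cc3)c3ccccc23)cc1` — 120 nM
compound 2 `CCOC(=O)c1ccc(-c2nn(Cc3cccnc3)c3ccccc23)cc1` — 5550 nM
compound 3 `CCOC(=O)c1ccc(-c2nn(-c3ccoc3)c3ccccc23)cc1` — 580 nM

Compound 1 gives the lowest number of the three in this assay, with compound 3 nearest and compound 2 furthest. It is the reference for compound 4 `CCCCn1nc(-c2ccc(C(=O)OCC)cc2)c2ccccc21`, not yet measured. The change from compound 1 to compound 4 is propyl in place of 4-chlorophenyl on a saturated chain carbon bound to an aromatic nitrogen.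

Going by the values given here, two measured steps bear on this, both altering the same group on the aromatic nitrogen of the shared core. a 46-fold higher number from compound 1 to compound 2 (1.67 log units; beyond the scatter). a 4.8-fold higher number from compound 1 to compound 3 (0.68 log units; beyond the scatter). Every alteration of the 4-chlorobenzyl group so far has weakened inhibition, once by a large margin and once modestly. Among the compounds with values here, the step to compound 4 goes further, removing the aromatic ring altogether in favour of a propyl chain; no measured pair shows this kind of change directly. A higher number is therefore expected for compound 4, plausibly between the two recorded losses, and a 13-fold higher number from compound 1 to compound 4 (1.10 log units; beyond the scatter) is the expected step. Compound 4 is estimated at 1500 nM, in a range from 400 nM to 6000 nM.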

Compound 4, half-maximal inhibitory concentration: 670 nM
For compound 4 the middle estimate is 2.2-fold (0.35 log units) above the measured one; the measured number falls inside the stated range.
By their numbers in this assay, from the lowest: compound 1; then compounds 3 and 4 (each within the scatter of the next); then compound 2.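

In this assay, the aromatic ring of the 4-chlorobenzyl group is not essential for inhibition at this position: the butyl group of compound 4 retains a good part of it, with a 5.6-fold higher number from compound 1 to compound 4 (0.75 log units; beyond the scatter), and shows a 1.2-fold higher number from compound 3 to compound 4 (0.06 log units; within the scatter), so it stands level with the furan-3-yl group. The plain chain also outperforms the (pyridin-3-yl)methyl group, with an 8.3-fold lower number from compound 2 to compound 4 (0.92 log units; beyond the scatter), so a ring on the saturated chain carbon bound to the aromatic nitrogen does not favour inhibition in itself: compound 1 gains from its ring-bearing group, while compound 2 goes against any such trend. No measured evidence accounts for these differences.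

An unsubstituted benzyl group would separate the contribution of the chlorine from that of the ring. As far as these compounds go, how a longer chain such as hexyl, or a chain ending in an amine, would compare on this nitrogen remains open.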